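The source may hold more compounds than are shown below. What is called first, only, known or untested is meant among the compounds shown, and "the series" means these compounds.

Compounds measured:
compound 1, `CCCCCCC(O)[C@H](CC(C)C)NC(=O)[C@@H](NC(=O)[C@@H](NC(=O)C(C)C)C(C)C)C(C)C`, 3600 nM in an assay on isolated protein (plant) for inhibition of Pepsin A (Sus scrofa); on this read-out higher numbers stand for weaker inhibition and lower numbers for stronger inhibition
compound 2, `CCCCCCC(O)[C@H](CC(C)C)NC(=O)[C@@H](NC(=O)[C@@H](NC(=O)OCc1ccccc1)C(C)C)C(C)C`, 690 nM in this assay
compound 3, `CCCCCCC(O)[C@H](CC(C)C)NC(=O)[C@@H](NC(=O)[C@@H](NC(=O)CC(C)C)C(C)C)C(C)C`, 920 nM in this assay

The three measured compounds share one core and differ only in the group carried on the terminal carbonyl carbon. Compound 2 gives the lowest number of the three in this assay: compound 3 stands nearest to it, and the step of a 1.3-fold higher number from compound 2 to compound 3 (0.12 log units; within the scatter) lies within the scatter, so the two cannot be ordered; compound 1 stands furthest, with a 5.2-fold lower number from compound 1 to compound 2 (0.72 log units; beyond the scatter).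

Compound 4, `CCCCCCC(O)[C@H](CC(C)C)NC(=O)[C@@H](NC(=O)[C@@H](NC(=O)OC(C)(C)C)C(C)C)C(C)C`, has not yet been measured. It differs from compound 2 in one place: tert-butyl in place of benzyl on an oxygen next to a carbonyl group. Benzyl carries one six-membered aromatic ring of carbon only, tert-butyl has no ring.

Within the data shown here, no measured step exchanges one group on this oxygen for another, so the bearing of the known steps is indirect. The steps of a 5.2-fold lower number from compound 1 to compound 2 (0.72 log units; beyond the scatter) and a 3.9-fold lower number from compound 1 to compound 3 (0.59 log units; beyond the scatter) show that the group on the terminal carbonyl carbon moves the number by a modest amount, while a 1.3-fold higher number from compound 2 to compound 3 (0.12 log units; within the scatter) shows that benzyloxy and isobutyl give numbers within the scatter of each other. On that basis compound 4 is expected to stay within a modest distance of compound 2, most likely with a somewhat higher number, an expected step of a 2.0-fold higher number from compound 2 to compound 4 (0.31 log units; beyond the scatter). For compound 4 the estimate in this assay is 1400 nM, with a range from 500 nM to 4000 nM.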

Compound 4, half-maximal inhibitory concentration: 210 nM
For compound 4 the middle estimate is 6.7-fold (0.82 log units) above the measured one, outside the stated range (below it).
By their numbers in this assay, from the lowest: compound 4; then compounds 2 and 3 (each within the scatter of the next); then compound 1.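

In this assay, the group on the oxygen next to a carbonyl group proves to matter in its own right: tert-butyl in place of benzyl gives a 3.3-fold lower number from compound 2 to compound 4 (0.52 log units; beyond the scatter), the only measured step that exchanges one group on this oxygen, so a six-membered aromatic ring there is not needed for the lowest number among these four compounds. The earlier compounds shown here placed benzyloxy and isobutyl within the scatter of each other, whereas tert-butoxy stands apart from isobutyl, with a 4.4-fold lower number from compound 3 to compound 4 (0.64 log units; beyond the scatter), and the span of groups on a carbonyl carbon now widens from modest to large, with a 17-fold lower number from compound 1 to compound 4 (1.23 log units; beyond the scatter). No measurement at hand accounts for why this exchange lowers the number.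

The compounds shown leave open whether the lower number goes with the branching of tert-butyl or with the loss of the ring, a question that methyl, ethyl or cyclohexylmethyl on this oxygen would help to settle. As far as these compounds go, it also remains open whether exchanging benzyl for tert-butyl would have a step of similar size on another core.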